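The source may hold more compounds than are shown below. What is called first, only, known or untested is meant among the compounds shown, and "the series" means these compounds.

Compound 1 `O=C(Nc1ccc(Oc2ccc(-c3nccs3)cc2)cc1)Nc1cc(C(F)(F)F)ccc1Cl` in a functional assay on A549 cells (Homo sapiens) for inhibition, read by MTT assay and WST assay, with a stated time of 72 h, tested at 10 uM (a lower number here means less inhibition of growth, a higher number more inhibition of growth at the concentration tested), gives 75.5%. Compound 2 `O=C(Nc1ccc(Oc2ccc(-c3nccs3)cc2)cc1)Nc1cc(Br)cc(C(F)(F)F)c1` gives 81.7%; the difference is 3-bromo-5-(trifluoromethyl)phenyl in place of 2-chloro-5-(trifluoromethyl)phenyl on an amide-type nitrogen, and the step is a number 6.2 percentage points higher from compound 1 to compound 2 (within the scatter). Going by the values given here, compound 3 `O=C(Nc1ccc(Oc2ccc(-c3ncc[nH]3)cc2)cc1)Nc1cc(C(F)(F)F)ccc1Cl` gives 22.3%; here the core differs from compound 1 by 1H-imidazol-2-yl in place of 1,3-thiazol-2-yl on an aromatic carbon, and the step is a number 53.2 percentage points lower from compound 1 to compound 3 (beyond the scatter), the only step among the three that is beyond the scatter.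

Compound 4 `O=C(Nc1ccc(Oc2ccc(-c3ncc[nH]3)cc2)cc1)Nc1cc(Br)cc(C(F)(F)F)c1` remains to be measured in this assay. Its difference from compound 3 is 3-bromo-5-(trifluoromethyl)phenyl in place of 2-chloro-5-(trifluoromethyl)phenyl on an amide-type nitrogen, the same change as from compound 1 to compound 2, made on the same place in words, but now on the core of compound 3. The starting point is compound 3 with 22.3%. Since a number 6.2 percentage points higher from compound 1 to compound 2 (within the scatter) lay within the scatter, the step for compound 4 is expected to be about as small, a number 5.7 percentage points higher from compound 3 to compound 4 (within the scatter). Compound 4 is therefore estimated at 28%, with a range from 12% to 46%.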

Compound 4, percent growth inhibition at one concentration: 44.1%
The estimate for compound 4 lay 16.1 percentage points below the measured number; low and high end bracket the measured number.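

In this assay the change to 3-bromo-5-(trifluoromethyl)phenyl gives a number 21.8 percentage points higher from compound 3 to compound 4 (beyond the scatter), so the size of this step depends on the core that carries it: the same change on two cores in this assay, a number 6.2 percentage points higher (within the scatter) from compound 1 to compound 2 and a number 21.8 percentage points higher (beyond the scatter) from compound 3 to compound 4, 15.6 percentage points apart, beyond the scatter of two such steps

Read the other way, 1H-imidazol-2-yl in place of 1,3-thiazol-2-yl gives a number 37.6 percentage points lower from compound 2 to compound 4 (beyond the scatter), a drop with either aryl group but not one of fixed size: the same change on two cores in this assay, a number 53.2 percentage points lower (beyond the scatter) from compound 1 to compound 3 and a number 37.6 percentage points lower (beyond the scatter) from compound 2 to compound 4, 15.6 percentage points apart, beyond the scatter of two such steps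

Going by these compounds alone, this shows that the two changes do not add up independently across these compounds, but with only two cores and two aryl groups it gives no cause and no general rule for the series.

Left open is how an amine or a nitrile in place of the bromine would read on either core. Also open, on these data alone, is how a carboxylic acid in place of the 1,3-thiazol-2-yl would read.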